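The source may report more compounds than this note shows. Statements on the series, on what has been measured and on what is new or still open speak of the compounds shown alone.

In a functional assay on LOX IMVI cells (Homo sapiens) for cytotoxicity, read by MTT assay, with a stated time of 24 h (on this read-out higher numbers stand for weaker inhibition and lower numbers for stronger inhibition), three compounds sharing one core have been measured. Compound 1 (`COc1cc(-c2nc(-c3ccccc3)[nH]c2-c2ccnc(NCCCNS(=O)(=O)c3ccc(Cl)cc3)n2)ccc1F`) gives 83100 nM, and compound 2 (`COc1cc(-c2nc(-c3ccccc3)[nH]c2-c2ccnc(NCCCNS(=O)(=O)c3ccc(F)cc3)n2)ccc1F`) gives 3960 nM. Compound 3 (`COc1cc(-c2nc(-c3ccccc3)[nH]c2-c2ccnc(NCCCNS(=O)(=O)c3ccc(Cl)cc3)n2)ccc1Cl`) gives 60900 nM, which lies within the scatter of compound 1 and well above the value of compound 2. Compound 4 (`COc1cc(-c2nc(-c3ccccc3)[nH]c2-c2ccnc(NCCCNS(=O)(=O)c3ccc(C)cc3)n2)ccc1Cl`) has not yet been measured. It differs from compound 3 by methyl in place of chloro on an aromatic carbon. Among the compounds with values here, two measured steps bear on this change. The closer one, a 21-fold lower number from compound 1 to compound 2 (1.32 log units; beyond the scatter), is large and replaces the same chloro, but with fluoro rather than methyl. The other, a 1.4-fold lower number from compound 1 to compound 3 (0.13 log units; within the scatter), exchanges a halogen elsewhere in the molecule and stays within the scatter. Within the data shown here, no measured compound carries this methyl, so the evidence is indirect. A moderate move toward a lower number is expected, smaller than the step to compound 2, and the estimated step is a 3.0-fold lower number from compound 3 to compound 4 (0.48 log units; beyond the scatter). For compound 4 the expected value is 20000 nM, with an estimated range of 3000 nM to 80000 nM.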

Compound 4, half-maximal inhibitory concentration: 18600 nM
For compound 4 the middle estimate is 1.1-fold (0.03 log units) above the measured one, within the range that was stated.
By their numbers in this assay, from the lowest: compound 2; then compound 4; then compounds 3 and 1 (each within the scatter of the next).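

In this assay the exchange of 4-chlorophenyl for 4-methylphenyl gives (a 3.3-fold lower number from compound 3 to compound 4 (0.52 log units; beyond the scatter)), which shows that this site also responds to a replacement that is not a halogen. Previously the only replacement of this chloro was fluoro (a 21-fold lower number from compound 1 to compound 2 (1.32 log units; beyond the scatter)), and that step has a fluoro rather than a chloro on the other aromatic ring; both replacements now lead to lower numbers, the fluoro step large and the methyl step modest. Nothing available gives a measured reason for either step.

As the two steps stand on different backgrounds, the compounds shown do not separate the entering group from the halogen elsewhere. Going by these compounds, how a methoxy, an amine or a carboxylic acid would behave at this place remains open.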